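The source may hold more compounds than are shown below. What is called first, only, known or untested is meant among the compounds shown, and "the series" means these compounds.

Working notes on the series. In an ADME assay on the whole organism (Rattus norvegicus, strain Wistar Han) for pharmacokinetics, read by LC-MS, with a stated time of 7 h, at a dose of 3 mg/kg by the oral route (a higher number here means that a larger share of the oral dose reaches the circulation, a lower number that a smaller share of the oral dose reaches the circulation), compound 1 `CNC(=O)c1cc(C(=O)N[C@H]2CC[C@H](O)CC2)c([C@@H](C)c2cccc(Cl)c2)o1` gives 37% and compound 2 `CNC(=O)c1cc(C(=O)N[C@H]2CC[C@H](O)CC2)n([C@@H](C)c2ccccc2)n1` gives 58%. Compound 2 therefore holds the higher of the two numbers, and its gap to compound 1 lies beyond the scatter. Among the measured compounds shown here, no measured pair differs in one place only, so the data offer no direct precedent for the size of any single structural step.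

The next compound to be read is compound 3 `CNC(=O)c1cc(C(=O)N[C@H]2CC[C@H](OC)CC2)n([C@@H](C)c2ccccc2)n1`. Its change from compound 2 is methyl in place of hydrogen on an oxygen on a saturated carbon, which turns hydroxy to methoxy and 4-hydroxycyclohexyl to 4-methoxycyclohexyl. For the measured compounds named here, with no precedent for this change, no step beyond the scatter is expected in this assay. Going by the values given here, a slight downward lean is allowed, resting only on compound 2 standing at 58%, the higher of the two numbers so far. The expected change is a number 6 percentage points lower from compound 2 to compound 3 (within the scatter), an estimate that stays within the scatter but carries wide uncertainty. Compound 3 is estimated at 52%, with an expected range of 30% to 75%.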

Compound 3, oral bioavailability: 80%
Estimate against measurement, compound 3: 28 percentage points below; the measured number lies above the stated range.
By their numbers in this assay, from the lowest: compound 1; then compound 2; then compound 3.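

Hydroxy to methoxy on the cyclohexyl group gives a number 22 percentage points higher from compound 2 to compound 3 (beyond the scatter) in this assay, the first step in the series measured between compounds that differ in one place only, so a change of a single methyl on this oxygen is enough to move the number beyond the scatter. At this position the free hydroxy is thus not needed for a high share of the oral dose to reach the circulation, at least on the core shared by compound 2 and compound 3, and the 4-methoxycyclohexyl group of compound 3 carries the number to 80%. The data shown hold no measurement that bears on what lies behind this step.

Going by these compounds, whether methoxy in place of hydroxy gives a step of similar size on the core of compound 1 remains open. Also open, on these data alone, is how the number responds to a longer chain on this oxygen, such as ethyl or 2-methoxyethyl, or to an amine in place of the methoxy group on the cyclohexyl ring.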